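Compound 1: allyl replaced by 4-methylphenyl

The source may hold more compounds than are shown below. What is called first, only, known or untested is meant among the compounds shown, and "the series" means these compounds.

Measured in a functional assay on HCT-116 cells (Homo sapiens) for antiproliferative activity, read by MTT assay, with a stated time of 72 h (on this read-out lower numbers stand for stronger inhibition and higher numbers for weaker inhibition), so far:
Compound 1 `C=CC/N=C1\S/C(=C\c2ccc(OC)cc2)C(=O)N1C` gives 79300 nM
Compound 2 `C=C1CN(C)/C(=N/c2ccccc2)S1` gives > 100000 nM (a limit, not a number)
Compound 3 `FC(F)(F)c1cc(/N=C2/NC/C(=C/c3ccccc3)S2)cc(C(F)(F)F)c1` gives 16100 nM

Of the two true numbers, the higher belongs to compound 1, and compound 3 lies lower by more than the usual scatter. The remaining entry is only a limit, so compound 1 cannot be ranked against compound 2.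

Compound 4 `COc1ccc(/C=C2\S/C(=N\c3ccc(C)cc3)N(C)C2=O)cc1` has not yet been measured. It keeps the core of compound 1 but has 4-methylphenyl in place of allyl on a double-bonded nitrogen.

Among the measured compounds shown here, no measured pair isolates this change, so the guidance is indirect. Compound 3 carries a six-membered aromatic ring of carbon only on its double-bonded nitrogen and gives 16100 nM, which suggests a lower number. Compound 2 also carries such a ring and goes against that suggestion. For compound 2, > 100000 nM is a limit.

A small step toward a lower number is therefore expected in this assay, close to the edge of the scatter. The expected change is a 2.0-fold lower number from compound 1 to compound 4 (0.30 log units; within the scatter), with low confidence. Compound 4 is estimated at 40000 nM, with an expected range from 12000 nM to 100000 nM.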

Compound 4, half-maximal inhibitory concentration: > 100000 nM
Compound 4: no number, only a limit; the forecaster's own chance of this, stated with the estimate: 20%; middle value at least 2.5-fold (0.39 log units) from the limit.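

In this assay compound 4 gives > 100000 nM, which is a limit and not a number. Among the compounds shown here, compound 1 and compound 4 form the first pair that isolates the double-bonded nitrogen, and placing 4-methylphenyl there instead of allyl on the shared core gives an at least 1.2-fold higher number from compound 1 to compound 4 (0.10 log units; that floor lies within the scatter). The pair therefore shows no lower number for this change, but the size of the step cannot be read further, and its floor does not establish a difference beyond the scatter, because the reading for compound 4 stops at a limit: the limit of > 100000 nM in this assay, at which 2 of the 4 values shown sit.

The compounds shown leave open how a longer alkyl chain or a chain carrying an amine would read at this place on the core of compound 1, and whether the methyl of 4-methylphenyl has any part in the step. Compound 2 and compound 3 differ from compound 1 in more than one place, so they do not settle whether another six-membered aromatic ring of carbon only at this place, on this core, would give a lower number.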